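Exchanging Nitro for Amino in an Antiproliferative Compound

The compounds below may be only part of what the source reports. "The series", "measured", "known", "first", "only" and "open" are said of these compounds alone.

Going by the values given here, in a functional assay on MDA-MB-468 cells (Homo sapiens) for antiproliferative activity, read by MTT assay, with a stated time of 72 h (a higher number here means a weaker inhibitor, a lower number a stronger inhibitor), compound 1 `COc1ccc(-n2ccnc2-c2cc(OC)c(OC)c(OC)c2)cc1[N+](=O)[O-]` gives 100 nM, the lowest number of the three measured so far. Compound 2 `COc1cc(-c2nccn2-c2ccc(C)cc2)cc(OC)c1OC` gives 400 nM, and compound 3 `COc1cc(-c2nccn2-c2cccc([N+](=O)[O-])c2)cc(OC)c1OC` gives 7200 nM. Compound 4 `COc1ccc(-n2ccnc2-c2cc(OC)c(OC)c(OC)c2)cc1N` has not yet been measured. It keeps the core of compound 1 but carries amino in place of nitro on an aromatic carbon, ortho to a methoxy group: amino in place of nitro on an aromatic carbon.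

Among the compounds with values here, no measured step makes this exchange. Within the data shown here, the only step that bears on it is a 72-fold higher number from compound 1 to compound 3 (1.86 log units; beyond the scatter), a large step with hydrogen in place of methoxy on an aromatic carbon. That step leaves the nitro group untouched, so it says nothing about the direction an amino group would take. Compound 4 retains the methoxy group, and a step of that size is not expected.

The expected change in this assay stays within the scatter, with an estimated 1.4-fold lower number from compound 1 to compound 4 (0.15 log units; within the scatter). For compound 4 the estimate is 70 nM, with an expected range from 15 nM to 400 nM.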

Compound 4, half-maximal inhibitory concentration: 90 nM
Estimate against measurement, compound 4: 1.3-fold (0.11 log units) below, within the range that was stated.
By their numbers in this assay, from the lowest: compounds 4 and 1 (each within the scatter of the next); then compound 2; then compound 3.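

In this assay, amino in place of nitro on this aromatic carbon, ortho to a methoxy group, gives a 1.1-fold lower number from compound 1 to compound 4 (0.05 log units; within the scatter), so the assay does not tell the two groups apart at this position. The earlier step, a 72-fold higher number from compound 1 to compound 3 (1.86 log units; beyond the scatter), showed how much hangs on the methoxy group while nitro stays in place, whereas this one shows that nitro itself can leave without a step beyond the scatter. No measurement offered here accounts for the two groups reading alike.

Going by these compounds, whether the position would also accept a hydroxyl group, an acetamide or a dimethylamino group remains open. So does whether amino would read the same with the methoxy group replaced by hydrogen, a pairing the compounds shown do not include.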